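A few compounds are considered here, and "the series" means these few. Any claim that something is new, unique, unknown or untested is made for them only; others in the source may bear on it.

Compound 1, `C#CCCCCOc1ccc2oc(=O)c(C(=O)OC)cc2c1`, and compound 2, `C#CCCCCOc1ccc2oc(=O)c(C(=O)c3ccc(OC)cc3)cc2c1`, share one core and differ only at the carbonyl carbon, where compound 2 carries 4-methoxyphenyl in place of methoxy. In an assay on cells for inhibition of Amine oxidase [flavin-containing] A (Homo sapiens), read by Amplex Red, with stated times of 30 min and 45 min (a higher number here means a weaker inhibitor, a lower number a stronger inhibitor), compound 1 gives > 10000 nM, which is a limit of the assay and not a number. Compound 2 gives > 10000 nM in this assay, again a limit and not a number. The step that the two limits leave unreadable from compound 1 to compound 2 is unreadable because both values sit at the limit of > 10000 nM in this assay, at which 2 of the 2 values shown sit. Compound 1 therefore stands only at a limit; no measured number places it within the series.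

Compound 3, `COC(=O)c1cc2cc(OCCc3ccc(Cl)cc3)ccc2oc1=O`, differs from compound 1 by 4-chlorophenyl in place of but-3-yn-1-yl on a saturated chain carbon, two bonds along the chain from an oxygen on an aromatic ring. No measured step bears on this change: the only step shown, a step that the two limits leave unreadable from compound 1 to compound 2, alters the group on the carbonyl carbon rather than the chain on the aromatic oxygen, and its size is not readable. The expectation for this assay thus rests on compound 1 alone, which sits at a limit, so no direction beyond the scatter is claimed and the estimated step of a number no higher from compound 1 to compound 3 (the limit leaves the size open) is set near zero. Compound 3 is expected to give 10000 nM in this assay, within 1500 nM to 50000 nM.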

Compound 3, half-maximal inhibitory concentration: > 10000 nM
Compound 3: a limit, no number; the forecaster's own chance of this, stated with the estimate: 60%; the middle value lies on the limit itself.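

No new step can be read from compound 3, since its comparison with compound 1 is unreadable, like that of compound 2 with compound 1, because all the values sit at one limit: the limit of > 10000 nM in this assay, at which 3 of the 3 values shown sit.

The compounds shown leave open how strongly any of them inhibits in this assay, and whether either change on the shared core alters that.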